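Dihydroxyphenyl for chlorophenyl: expected cytotoxicity of compound 3

A few compounds are considered here, and "the series" means these few. Any claim that something is new, unique, unknown or untested is made for them only; others in the source may bear on it.

In a functional assay on U-87MG ATCC cells (Homo sapiens) for cytotoxicity, read by MTT assay, with a stated time of 72 h (a lower number here means a stronger inhibitor, a higher number a weaker inhibitor), compound 1 `CN(C)CCn1cnnc1-c1cc(Oc2ccc(NC(=O)N/N=C/c3ccc(F)cc3Cl)cc2F)ccn1` gives 1210 nM. Compound 2 `CN(C)CCn1cnnc1-c1cc(Oc2ccc(NC(=O)N/N=C/c3ccc(Cl)cc3)cc2F)ccn1` gives 1370 nM in this assay; the two values lie within the scatter of each other, so compound 2 stands level with compound 1 on the numbers shown. Compound 3 `CN(C)CCn1cnnc1-c1cc(Oc2ccc(NC(=O)N/N=C/c3ccc(O)c(O)c3)cc2F)ccn1` carries 3,4-dihydroxyphenyl in place of 4-chlorophenyl on a carbon with a double bond to nitrogen. Within the data shown here, the only step that bears on this site, a 1.1-fold higher number from compound 1 to compound 2 (0.05 log units; within the scatter), left the number unchanged, so no step beyond the scatter is expected for compound 3, though the entering group with its hydrogen-bond donors and acceptors is a larger change than the earlier one, so the range is kept wide. Compound 3 is expected at 1500 nM, range 600 nM to 4000 nM. The expected step is a 1.1-fold higher number from compound 2 to compound 3 (0.04 log units; within the scatter).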

Compound 3, half-maximal inhibitory concentration: > 100000 nM
Compound 3 was reported as a limit; the forecaster's own chance of this, stated with the estimate: 5%; at least 66-fold (1.82 log units) between middle value and limit.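

In this assay the substituent on the carbon with a double bond to nitrogen matters: 4-chlorophenyl and 2-chloro-4-fluorophenyl stand level, so the earlier pair gave no sign of this sensitivity, yet 3,4-dihydroxyphenyl brings an at least 72-fold higher number from compound 2 to compound 3 (1.86 log units; beyond the scatter) and an at least 82-fold higher number from compound 1 to compound 3 (1.91 log units; beyond the scatter). The value of compound 3 is a limit, not a number: the limit of > 100000 nM in this assay, at which 1 of the 3 values shown sits.

The compounds shown cannot tell whether this step needs both hydroxyl groups or follows from a single one. As far as these compounds go, how a phenyl ring carrying methoxy groups or an amine would read at this place also remains open.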